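Working notes: cytotoxicity step from compound 2 to compound 3

The source may report more compounds than this note shows. Statements on the series, on what has been measured and on what is new or still open speak of the compounds shown alone.

Compound 1 `CCCCCCn1cc(COc2ccc(-c3cc(-c4ccc(C(C)C)cc4)nc(N)n3)c(O)c2)nn1` carries no result in an ADME assay on cells (Macrophage) for cytotoxicity, read by resazurin assay, with a stated time of 48 h; on this read-out lower numbers stand for higher toxicity in this test and higher numbers for lower toxicity in this test; for compound 1 the entry reads "not determined" (no result reported). Compound 2 `CC(C)c1ccc(-c2cc(-c3ccc(OCc4cn(Cc5ccccc5)nn4)cc3O)nc(N)n2)cc1` is the one measured entry in this assay, and in this assay compound 2 gives > 100000 nM, which is a limit of the assay and not a number. Among the measured compounds shown here, compound 2 therefore sits at the limit of > 100000 nM in this assay, at which 1 of the 2 values shown sits, and with the other entry lacking a single number there is no measured compound against which to place it. Compound 3 `Nc1nc(-c2ccccc2)cc(-c2ccc(OCc3cn(Cc4ccccc4)nn3)cc2O)n1` awaits measurement in this assay. Against compound 2 the difference is hydrogen in place of isopropyl on an aromatic carbon. For the measured compounds named here, no measured pair shows this change, so its size cannot be read from the data. Compound 3 is expected to show a step that the limit leaves unreadable from compound 2 to compound 3 that stays within the scatter, since compound 2 already rests at the limit. Compound 3 is thus estimated at 150000 nM, with a range from 50000 nM to 500000 nM, and a limit rather than a number is the likelier report.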

Compound 3, half-maximal cytotoxic concentration: 76500 nM
Estimate against measurement, compound 3: 2.0-fold (0.29 log units) above; measured number inside the range.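

In this assay compound 3 gives 76500 nM, the only single number among the compounds shown, so this position now has a measured value with hydrogen on the aromatic carbon. The change from 4-isopropylphenyl to phenyl gives an at least 1.3-fold lower number from compound 2 to compound 3 (0.11 log units; that floor lies within the scatter), and that floor does not establish a difference between the two compounds. The true size of the step stays unread because compound 2 rests on a limit of the assay and not a number: the limit of > 100000 nM in this assay, at which 1 of the 3 values shown sits.

From the compounds shown here alone, whether an amine, a carboxylic acid or a longer chain in place of isopropyl would move the number in this assay stays open. With a single numeric value in the series, no trend at this position can be stated.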